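Aromatic iodophenyl group replacing cyclohexyl on the purine core

The compounds below may be only part of what the source reports. "The series", "measured", "known", "first", "only" and "open" are said of these compounds alone.

For the measured compounds named here, compound 1 `OC[C@H]1O[C@@H](n2cnc3c(SC4CCCCC4)ncnc32)[C@H](O)[C@@H]1O` is one of three compounds measured in an assay on isolated protein for binding affinity to Equilibrative nucleoside transporter 1 (Homo sapiens); on this read-out higher numbers stand for weaker inhibition and lower numbers for stronger inhibition. In this assay compound 1 gives 6310 nM, which places it second highest of the three numbers: compound 2 `Nc1nc(SCc2ccc(Br)cc2)c2ncn([C@@H]3O[C@H](CO)[C@@H](O)[C@H]3O)c2n1` gives 813 nM, while compound 3 `CC(=O)c1cc(Cl)ccc1Sc1nc(N)nc2c1ncn2[C@@H]1O[C@H](CO)[C@@H](O)[C@H]1O` gives 14500 nM. Going by the values given here, the only one-place step among them runs an 18-fold higher number from compound 2 to compound 3 (1.25 log units; beyond the scatter), showing that the nature of the group on the sulfur can move this read-out strongly.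

Compound 4 `OC[C@H]1O[C@@H](n2cnc3c(CSc4cccc(I)c4)ncnc32)[C@H](O)[C@@H]1O` has not yet been measured. It differs from compound 1 in that (a group of 9 heavy atoms (7 carbon, 1 sulfur, 1 iodine; one six-membered aromatic ring of carbon only) in place of a group of 7 heavy atoms (6 carbon, 1 sulfur; one six-membered non-aromatic ring of carbon only), on an aromatic carbon). Among the compounds with values here, no measured step copies this change, since compound 2 and compound 3 carry a different core. Yet compound 2, whose sulfur carries an aromatic ring with a one-carbon link, has the lowest number shown, and compound 3, with the aromatic ring directly on the sulfur, the highest. Because compound 2 gives 813 nM, a moderate step downward is expected for compound 4, about a 3.2-fold lower number from compound 1 to compound 4 (0.50 log units; beyond the scatter). Compound 4 is therefore estimated at 2000 nM, in the range 400 nM to 10000 nM.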

Compound 4, half-maximal inhibitory concentration: 245 nM
The estimate for compound 4 lay 8.2-fold (0.91 log units) above the measured number; measured number outside the range, below it.
By their numbers in this assay, from the lowest: compound 4; then compound 2; then compound 1; then compound 3.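

In this assay the change on the aromatic carbon of the shared core gives a 26-fold lower number from compound 1 to compound 4 (1.41 log units; beyond the scatter), the first step shown on this core and the first downward step among those listed. The position therefore accepts the larger group of compound 4 in place of cyclohexylsulfanyl, with a large change in the number, although this single step replaces the ring, brings in iodine and alters the link to the core all at once. Nothing measured here accounts for the size of this step.

The compounds shown leave open how much of the step belongs to the iodine, the aromatic ring or the link, which a plain phenyl or a methoxy in the iodine's place on this core could begin to separate. They also leave open whether an amine added to the core of compound 4 would raise or lower the number.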